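This account rests on a few compounds, and the source may have more. Where it says the series, first, only, none or still open, it means among the compounds named here.

In a functional assay on B16 cells (Mus musculus) for cytotoxicity, read by MTT assay, with a stated time of 48 h (on this read-out higher numbers stand for weaker inhibition and lower numbers for stronger inhibition), compound 1 (`C#CC(=O)Nc1cccc(C#C)c1`) gives 300 nM and so holds the lower of the two actual numbers. Compound 2 (`C#Cc1cccc(NC(=O)c2cn(CC(=O)OCC)nn2)c1`) gives 91000 nM which lies well beyond the scatter from compound 1. Compound 3 (`CCOC(=O)Cn1cc(C(=O)Nc2cccc(-c3cn(CC(=O)OCC)nn3)c2)nn1`) stands at > 100000 nM which is a limit and not a number. Compound 4 (`C#CC(=O)Nc1ccccc1`) differs from compound 1 in one place, with hydrogen in place of ethynyl on an aromatic carbon. For the measured compounds named here, no measured pair isolates this change. Compound 2 still carries that ethynyl and gives 91000 nM so the group alone does not bring a low number, while compound 4 keeps the amide side of compound 1 unchanged. In this assay a modest step towards a higher number is therefore expected, of about the size of the scatter or a little beyond it. The estimated change is a 3.0-fold higher number from compound 1 to compound 4 (0.48 log units; beyond the scatter). For compound 4 the expected value is 900 nM with an estimated range from 200 nM to 5000 nM in this test.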

Compound 4, half-maximal inhibitory concentration: 6200 nM
For compound 4 the middle estimate is 6.9-fold (0.84 log units) below the measured one, outside the stated range (above it).
By their numbers in this assay, from the lowest: compound 1; then compound 4; then compound 2. At a limit, above all of these: compound 3.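

Hydrogen in place of ethynyl on the aromatic carbon gives, in this assay, a 21-fold higher number from compound 1 to compound 4 (1.32 log units; beyond the scatter), so this carbon, meta to a group of 5 heavy atoms, is far from indifferent to what it carries. For the compounds shown here, no earlier pair isolated this change, and this step is the first direct reading of the ethynyl at this place, with the rest of compound 1 left as it was. Nothing measured here accounts for the size of the step.

Going by these compounds, whether the step belongs to the ethynyl itself stays open, as a nitrile, a methyl or an amine at the same carbon could show. On these data alone, whether the ethynyl counts for as much with another amide side also stays open: this single pair cannot tell.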